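Trifluoromethoxy in place of fluoro: the step to compound 4

The source may report more compounds than this note shows. Statements on the series, on what has been measured and on what is new or still open speak of the compounds shown alone.

In a functional assay on HepG2 cells (Homo sapiens) for antiproliferative activity, read by CCK-8 assay, with a stated time of 48 h (on this read-out lower numbers stand for stronger inhibition and higher numbers for weaker inhibition), compound 1 (`COc1ccc2sc(NC(=O)c3cc(=O)c4ccccc4o3)nc2c1`) gives 660 nM and compound 3 (`O=C(Nc1nc2cc(F)ccc2s1)c1cc(=O)c2ccccc2o1`) gives 850 nM while compound 2 (`O=C(Nc1nc(-c2ccc(F)cc2)cs1)c1cc(=O)c2ccccc2o1`) gives 950 nM on the same read-out. Compound 2 thus stands within the scatter of both other compounds, and the three cannot be ranked. The change from compound 2 to the unmeasured compound 4 (`O=C(Nc1nc(-c2ccc(OC(F)(F)F)cc2)cs1)c1cc(=O)c2ccccc2o1`) is trifluoromethoxy in place of fluoro on an aromatic carbon, para to a large group (trifluoromethoxy in place of fluoro on an aromatic carbon).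

Going by the values given here, only one measured step comes near this change: a 1.3-fold higher number from compound 1 to compound 3 (0.11 log units; within the scatter) for fluoro in place of methoxy on an aromatic carbon. That step sits on the core of compound 1, not the core of compound 2, and methoxy is not trifluoromethoxy, so it is only an indirect guide. Among the compounds with values here, no measured step involves trifluoromethoxy itself. In this assay a step beyond the scatter is therefore not expected, and the data favour no firm direction. The expected move is a 1.2-fold lower number from compound 2 to compound 4 (0.07 log units; within the scatter) and this estimate stays within the scatter. For compound 4 the estimated value is 800 nM with 300 nM to 2200 nM as the expected range.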

Compound 4, half-maximal inhibitory concentration: 1040 nM
Compound 4: the middle estimate sits 1.3-fold (0.11 log units) below what was measured; measured number inside the range.
By their numbers in this assay, from the lowest: compounds 1, 3, 2 and 4 (each within the scatter of the next).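

In this assay, exchanging fluoro for trifluoromethoxy on an aromatic carbon, para to a large group, gives a 1.1-fold higher number from compound 2 to compound 4 (0.04 log units; within the scatter), even though the entering group has 5 heavy atoms against 1 for fluoro and carries 1 hydrogen-bond acceptor. Going by these compounds alone, the only earlier step lay on the core of compound 1, so this is the first direct reading at this position, and it shows that, for this one pair, the larger group leaves the number within the scatter. Nothing measured here bears on why the number stays within the scatter, so the result stands as an observation only.

The compounds shown leave open whether a group of a different kind at this position, such as an amine or a carboxylic acid, would give a step beyond the scatter. They also leave open whether trifluoromethoxy in place of fluoro would read the same on the core of compound 3, where fluoro also sits on an aromatic carbon.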